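The source may hold more compounds than are shown below. What is called first, only, known or untested is meant among the compounds shown, and "the series" means these compounds.

Measured so far in an assay on isolated protein for inhibition of leukotriene B4 receptor 1 (Homo sapiens), tested at 10 uM; a higher number here means more inhibition at the concentration tested (going by the name of the read-out), a lower number less inhibition:
compound 1 `C=CCc1cc(C(C)=O)c(O)cc1OCC#N` — 20%
compound 2 `C=CCc1cc(C(C)=O)c(O)cc1OCCCCCCCC#N` — 88%
compound 3 `C=CCc1cc(C(C)=O)c(O)cc1OCCCCCCCCCCC#N` — 50%

Compound 3 stands second of these three numbers, with compound 2 above it and compound 1 below it, both gaps beyond the scatter. Compound 4 `C=CCc1cc(C(C)=O)c(O)cc1OCCCCC` differs from compound 3 in one place: hydrogen in place of 5-cyanopentyl on a saturated chain carbon, five bonds along the chain from an oxygen on an aromatic ring. Going by the values given here, only one measured step touches a change of this kind, the cut of the chain a number 38 percentage points lower from compound 2 to compound 3 (beyond the scatter), and it ran downward. Among the compounds with values here, compound 4 keeps an even shorter chain and gives up the nitrile as well, so no step matches it closely; compound 1, which also has a short chain, gives 20%. A fall from compound 3 is therefore expected, around a number 15 percentage points lower from compound 3 to compound 4 (beyond the scatter). The estimate for compound 4 is 35%, ranging from 10% to 70%.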

Compound 4, a percentage reported as inhibition, at one concentration (the size of the read-out at that concentration, not a potency): 60%
The estimate for compound 4 lay 25 percentage points below the measured number, within the range that was stated.
By their numbers in this assay, from the lowest: compound 1; then compounds 3 and 4 (each within the scatter of the next); then compound 2.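

In this assay, the step of a number 10 percentage points higher from compound 3 to compound 4 (within the scatter) shows that removing the 5-cyanopentyl group, nitrile included, leaves a result that cannot be told apart from the long nitrile chain. The plain chain still stands clear of the shortest nitrile chain, with a number 40 percentage points higher from compound 1 to compound 4 (beyond the scatter) as the step, while a number 28 percentage points lower from compound 2 to compound 4 (beyond the scatter) leaves it behind the intermediate nitrile chain. Nothing measured here explains these differences.

Going by these compounds, it remains open whether the nitrile itself matters at the chain length of compound 2. Also open, on these data alone, is how a carboxylic acid or an amine at the chain end would compare.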